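This account rests on a few compounds, and the source may have more. Where it says the series, first, only, none or still open, it means among the compounds named here.

Measured compounds:
compound 1 `Cc1ccc2c(NCc3ccc(NC(=O)C4CCN(Cc5ccccc5)CC4)cc3)nc(N3CCC3)nc2c1` — in a functional assay on SV5A8 cells (Homo sapiens) for cytotoxicity (on this read-out lower numbers stand for stronger inhibition and higher numbers for weaker inhibition), a limit, > 8500 nM
compound 2 `Cc1ccc2c(NCc3ccc(NC(=O)C4CCN(Cc5ccc(Cl)cc5)CC4)cc3)nc(N(C)C)nc2c1` — in this assay a limit, > 3180 nM
compound 3 `Cc1ccc2c(NCc3ccc(NC(=O)C4CCN(C(=O)OC(C)(C)C)CC4)cc3)nc(N(C)C)nc2c1` — in this assay a limit, > 4820 nM

Compound 1 gives only a limit in this assay, so its standing cannot be placed against the others beyond that. Compound 2 sits at the limit of > 3180 nM in this assay, at which 1 of the 3 values shown sits. Compound 3 sits at the limit of > 4820 nM in this assay, at which 1 of the 3 values shown sits. Compound 1 itself sits at the limit of > 8500 nM in this assay, at which 1 of the 3 values shown sits. For the measured compounds named here, the only single-point step among them, a step that the two limits leave unreadable from compound 2 to compound 3, concerns the amine nitrogen in a ring and says nothing about the position changed here.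

Compound 4 `Cc1ccc2c(NCc3ccc(NC(=O)C4CCN(Cc5ccccc5)CC4)cc3)nc(N3CCC(N4CCCC4)CC3)nc2c1` differs from compound 1 by 4-(pyrrolidin-1-yl)piperidin-1-yl in place of azetidin-1-yl on an aromatic carbon. Going by the values given here, no measured step touches this aromatic carbon, and every value shown is a limit, so nothing in the data points to a gain or a loss from this change. The expectation therefore rests on the limits alone. Compound 4 is expected to give roughly 12000 nM in this assay, with a range from 3000 nM to 50000 nM, most probably again reported as a limit. The step this estimate means, a step that the limit leaves unreadable from compound 1 to compound 4, is expected to be none beyond the scatter.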

Compound 4, half-maximal inhibitory concentration: > 8090 nM
Compound 4 was reported as a limit (the forecaster's own chance of this, stated with the estimate: 70%); the middle value is on the limit's open side.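

Compound 1 and compound 4 are both reported only as limits in this assay, so no step can be read from one to the other. The compounds shown leave open where their actual values lie and whether the change on this aromatic carbon has any effect.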